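The source may report more compounds than this note shows. Statements on the series, on what has been measured and on what is new or still open speak of the compounds shown alone.

Measured so far in a functional assay on SK-OV-3 cells (Homo sapiens) for antiproliferative activity, read by MTT assay, with a stated time of 72 h; a lower number here means a stronger inhibitor, a higher number a weaker inhibitor:
Compound 1 `CC(C)(C)NC(=O)CCc1cccc2c1B(O)OC2` reaches only a limit, > 100000 nM.
Compound 2 `O=C(CCc1cccc2c1B(O)OC2)Nc1ccc(I)cc1` gives 51000 nM.

Going by the values given here, compound 2 thus holds the only number in this assay; the other value is a limit (the limit of > 100000 nM in this assay, at which 1 of the 2 values shown sits). Among the compounds with values here, the one measured step, an at least 1.9-fold lower number from compound 1 to compound 2 (0.29 log units; that floor lies within the scatter), is 4-iodophenyl in place of tert-butyl on an amide-type nitrogen, and its floor lies within the scatter.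

Compound 3 `O=C(CCc1cccc2c1B(O)OC2)Nc1ccc([N+](=O)[O-])cc1` differs from compound 2 by nitro in place of iodo on an aromatic carbon. Within the data shown here, no measured step changes a group on the aromatic ring, so the step from compound 1 to compound 2 bears on it only loosely. In this assay compound 3 is expected to sit near compound 2, with a 1.0-fold lower number from compound 2 to compound 3 (0.01 log units; within the scatter) not beyond the scatter. The estimate for compound 3 is 50000 nM, range 15000 nM to 120000 nM.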

Compound 3, half-maximal inhibitory concentration: 83000 nM
The estimate for compound 3 lay 1.7-fold (0.22 log units) below the measured number, within the range that was stated.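

In this assay, going by these compounds alone, the first change on the aromatic ring gives a 1.6-fold higher number from compound 2 to compound 3 (0.21 log units; within the scatter), so nitro and iodo cannot be told apart at this carbon, para to a large group. Iodo and nitro differ in heavy atoms and hydrogen-bond acceptors, yet the two compounds stay within the scatter of each other. Compound 1 remains the only compound at a limit: the limit of > 100000 nM in this assay, at which 1 of the 3 values shown sits.

Open, on these data alone, is whether an amine or a carboxylic acid at this ring carbon would move the number beyond the scatter. Also open, as far as these compounds go, is whether a longer chain between the amide and the shared core would do so.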